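Alkyne substituent changes on the shared core, CCRF-CEM series

A few compounds are considered here, and "the series" means these few. Any claim that something is new, unique, unknown or untested is made for them only; others in the source may bear on it.

Three compounds with the shared core of compound 1 `Cc1ccc(C#Cc2cn(C/C=C\CN3C(=O)c4ccccc4C3=O)c(=O)[nH]c2=O)cc1` have been measured in a functional assay on CCRF-CEM cells (Homo sapiens) for antiproliferative activity, read by MTT assay, with a stated time of 3 days; a higher number here means a weaker inhibitor, a lower number a stronger inhibitor. Compound 1 gives 238000 nM. Compound 2 `CCCCCCCCC#Cc1cn(C/C=C\CN2C(=O)c3ccccc3C2=O)c(=O)[nH]c1=O` gives 39000 nM, and compound 3 `O=C1c2ccccc2C(=O)N1C/C=C\Cn1cc(C#Cc2ccc(Br)cc2)c(=O)[nH]c1=O` gives 80000 nM. Compound 3 therefore holds the second highest of the three numbers, with compound 2 nearest and compound 1 furthest. The step of a 3.0-fold lower number from compound 1 to compound 3 (0.47 log units; beyond the scatter) and the step of a 2.1-fold higher number from compound 2 to compound 3 (0.31 log units; beyond the scatter) both lie beyond the scatter, as does the step of a 6.1-fold lower number from compound 1 to compound 2 (0.79 log units; beyond the scatter).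

Compound 4 `CCCCCc1ccc(C#Cc2cn(C/C=C\CN3C(=O)c4ccccc4C3=O)c(=O)[nH]c2=O)cc1` differs from compound 3 in one place: pentyl in place of bromo on an aromatic carbon. Among the compounds with values here, no measured step covers this exact change. Within the data shown here, two steps bear on it indirectly. The methyl of compound 1 sits on the same aromatic carbon, and the step of a 3.0-fold lower number from compound 1 to compound 3 (0.47 log units; beyond the scatter) shows that exchanging it for bromo lowered the number. The step of a 6.1-fold lower number from compound 1 to compound 2 (0.79 log units; beyond the scatter) shows that a long alkyl chain on the triple-bonded carbon gave a lower number than 4-methylphenyl. Pentyl is an alkyl like methyl but longer, so the expectation for compound 4 is a small move, most likely a somewhat lower number than compound 3, though a number near or above it would not surprise. The estimated step is a 1.5-fold lower number from compound 3 to compound 4 (0.16 log units; within the scatter). Compound 4 is thus expected at about 55000 nM, within a range of 18000 nM to 170000 nM.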

Compound 4, half-maximal inhibitory concentration: 102000 nM
Compound 4: the middle estimate sits 1.9-fold (0.27 log units) below what was measured, within the range that was stated.
By their numbers in this assay, from the lowest: compound 2; then compounds 3 and 4 (each within the scatter of the next); then compound 1.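

In this assay, pentyl in place of bromo on this aromatic carbon gives a 1.3-fold higher number from compound 3 to compound 4 (0.11 log units; within the scatter) and so does not separate the two groups, despite the difference between five carbons and one bromine. With a 2.3-fold lower number from compound 1 to compound 4 (0.37 log units; beyond the scatter) as the step from the methyl compound, the longer chain also gives a number beyond the scatter of compound 1, so methyl is now set apart from both pentyl and bromo, and among the three groups tried here the change in number does not simply follow the size of the group. Replacing octyl on the triple-bonded carbon with 4-pentylphenyl gives a 2.6-fold higher number from compound 2 to compound 4 (0.42 log units; beyond the scatter) and leaves compound 2 with the lowest number of the set, so neither aryl substituent beyond methyl has closed the gap to the octyl chain.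

As far as these compounds go, it remains open whether a longer chain, an amine or a carboxylic acid on this aromatic carbon would move the number beyond the scatter of compound 3. No data are available that explain these differences.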